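The source may report more compounds than this note shows. Statements on the series, on what has been measured and on what is new or still open speak of the compounds shown alone.

Of the compounds shown here, three sharing one core have been tested in a functional assay on ECa-109 cells (Homo sapiens) for antiproliferative activity, read by MTT assay, with a stated time of 48 h; a lower number here means a stronger inhibitor, a higher number a weaker inhibitor. Compound 1 (`Cn1cc(C2=C(c3nn(CCCN4CCCCC4)c4ncccc34)C(=O)N(c3ccccc3)C2=O)c2ccccc21`) gives 12300 nM, compound 2 (`Cn1cc(C2=C(c3nn(CCn4ccnc4)c4ncccc34)C(=O)N(c3ccccc3)C2=O)c2ccccc21`) gives 8770 nM, and compound 3 (`Cn1cc(C2=C(c3nn(CCCN4CCCCC4)c4ncccc34)C(=O)N(c3ccccn3)C2=O)c2ccccc21`) gives 7300 nM. Compound 3 lies within the scatter of both other compounds, so the numbers do not separate the three.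

Compound 4 (`COc1ccc(N2C(=O)C(c3cn(C)c4ccccc34)=C(c3nn(CCCN4CCCCC4)c4ncccc34)C2=O)cc1`) differs from compound 3 in one place, with 4-methoxyphenyl in place of pyridin-2-yl on an amide-type nitrogen in a ring. The closest evidence is the exchange at that same nitrogen, a 1.7-fold lower number from compound 1 to compound 3 (0.23 log units; within the scatter), where pyridin-2-yl replaced phenyl. The other measured step, a 1.4-fold lower number from compound 1 to compound 2 (0.15 log units; within the scatter), lies at a different place on the molecule and bears on the question only indirectly, as a second small difference. Going by the values given here, no tested compound carries 4-methoxyphenyl, so the data do not show what the methoxy group itself contributes. With neither measured step beyond the scatter, no step beyond the scatter is expected in this assay, and no direction can be firmly assigned. The expected step is a 1.4-fold higher number from compound 3 to compound 4 (0.14 log units; within the scatter), which would stay within the scatter. For compound 4 the estimated value is 10000 nM, with an expected range of 4500 nM to 22000 nM.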

Compound 4, half-maximal inhibitory concentration: 3340 nM
Beside the measured number, compound 4's estimate is 3.0-fold (0.48 log units) above it, outside the stated range (below it).
By their numbers in this assay, from the lowest: compound 4; then compounds 3, 2 and 1 (each within the scatter of the next).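

At the amide-type nitrogen in a ring, this assay now gives steps beyond the scatter, where the earlier exchange of phenyl for pyridin-2-yl stayed within it: a 2.2-fold lower number from compound 3 to compound 4 (0.34 log units; beyond the scatter), and a 3.7-fold lower number from compound 1 to compound 4 (0.57 log units; beyond the scatter). Going by these compounds alone, the second of these steps is the cleaner reading of the new group, since methoxy in place of hydrogen on the aromatic carbon is its only change, and it shows that this single addition to the phenyl ring on that nitrogen is enough to move the number modestly, though both steps remain small in size. Nothing measured here gives a reason for this shift.

The compounds shown leave open whether another group on the same phenyl ring, such as the hydroxy group of a 4-hydroxyphenyl or the chlorine of a 4-chlorophenyl, would lower the number as methoxy does. From the compounds shown here alone, it also remains open whether 4-methoxyphenyl would give a similar step on the core of compound 2, with its 1H-imidazol-1-yl group in place of the piperidine-bearing chain.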